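The compounds below may be only part of what the source reports. "The series", "measured", "known", "first", "only" and "open" are said of these compounds alone.

Compound 1 has the structure `CNC(=O)CSc1nc2ccc(NC(=O)CCl)cc2s1` and in a functional assay on HepG2 cells (Homo sapiens) for cytotoxicity, read by MTT assay, with a stated time of 48 h (on this read-out higher numbers stand for weaker inhibition and lower numbers for stronger inhibition), compound 1 gives 1900 nM.
Compound 2 has the structure `CNC(=O)CSc1nc2ccc(NC(=O)c3ccc([N+](=O)[O-])cc3)cc2s1`; in this assay compound 2 gives only a limit, > 100000 nM.
Compound 3 has the structure `O=C(CSc1nc2ccc(NC(=O)c3ccc([N+](=O)[O-])cc3)cc2s1)NCc1ccc(Cl)cc1`; in this assay compound 3 likewise gives only a limit, > 100000 nM.

Within the data shown here, the one change that has been measured is the move from compound 2 to compound 1, which is chloromethyl in place of 4-nitrophenyl on a carbonyl carbon. It produced an at least 52-fold lower number from compound 2 to compound 1 (1.72 log units; beyond the scatter), a step that sets out from the limit described by the limit of > 100000 nM in this assay, at which 2 of the 3 values shown sit.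

The cores of compound 3 and compound 2 differ by 4-chlorophenyl in place of hydrogen on a saturated chain carbon bound to an amide-type nitrogen. Because both values sit on the limit (the limit of > 100000 nM in this assay, at which 2 of the 3 values shown sit), the step that the two limits leave unreadable from compound 2 to compound 3 cannot be read.

Compound 4, `O=C(CSc1nc2ccc(NC(=O)CCl)cc2s1)NCc1ccc(Cl)cc1`, has not yet been measured. It differs from compound 3 by chloromethyl in place of 4-nitrophenyl on a carbonyl carbon, the same change, at the same place, that was made from compound 2 to compound 1. The expectation for compound 4 rests on that step: its value in this assay is expected to fall away from the limit of compound 3 by about an at least 40-fold lower number from compound 3 to compound 4 (1.60 log units; beyond the scatter), since the corresponding move gave an at least 52-fold lower number from compound 2 to compound 1 (1.72 log units; beyond the scatter). Compound 4 is therefore estimated at 2500 nM, within 500 nM to 15000 nM.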

Compound 4, half-maximal inhibitory concentration: 1800 nM
Compound 4: the middle estimate sits 1.4-fold (0.14 log units) above what was measured; measured number inside the range.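

The change from 4-nitrophenyl to chloromethyl on a carbonyl carbon carried over to the second core in this assay, giving an at least 55-fold lower number from compound 3 to compound 4 (1.74 log units; beyond the scatter), and it can be set beside the first case on two cores only: the same change on two cores in this assay, an at least 52-fold lower number (1.72 log units; beyond the scatter) from compound 2 to compound 1 and an at least 55-fold lower number (1.74 log units; beyond the scatter) from compound 3 to compound 4; the limit leaves it open whether they differ With chloromethyl in place, the two cores read alike, with a 1.1-fold lower number from compound 1 to compound 4 (0.02 log units; within the scatter), so the 4-chlorophenyl group left the value within the scatter in this pair. What this does not show is the true size of the change on either core, since both steps set out from a limit, and the step between the two 4-nitrophenyl compounds cannot be read: the limit of > 100000 nM in this assay, at which 2 of the 4 values shown sit.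

The compounds shown leave open whether the same fall would appear with a plain methyl, a bromomethyl or an unsubstituted phenyl on that carbonyl carbon. They also leave open whether the two chloromethyl cores would still read alike with a longer chain, an amine or a carboxylic acid in place of the 4-chlorophenyl group.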